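A few compounds are considered here, and "the series" means these few. Any claim that something is new, unique, unknown or untested is made for them only; others in the source may bear on it.

In an ADME assay on the whole organism for inhibition, with Echinochloa crus-galli var. formosensis as the target, with a stated time of 4 days (on this read-out higher numbers stand for weaker inhibition and lower numbers for stronger inhibition), compound 3 `CCNc1nc(Cl)nc(N[C@H](C)c2ccccc2)n1` gives 2690 nM. Compound 1 `CCN(CC)c1nc(Cl)nc(NC(C)c2ccccc2)n1` gives 1510 nM, which lies within the usual scatter of compound 3, while compound 2 `CCNc1nc(Cl)nc(N[C@@H](C)c2ccccc2)n1` gives the highest number of the three, 30900 nM. Compound 4 `CCNc1nc(Cl)nc(NC(C)c2ccccc2)n1` changes only this: the two compounds have the same atoms and bonds; at least one stereo element is drawn with a configuration in one of them and without one in the other: 1 of 1 stereo elements differ; a stereocentre at a saturated chain carbon is drawn R in compound 3 and without a configuration in compound 4. Among the compounds with values here, the one measured step that bears on this change is an 11-fold lower number from compound 2 to compound 3 (1.06 log units; beyond the scatter), a large step that rests on (the fact that compounds 2 and 3 differ only in the configuration as drawn). With no configuration drawn, compound 4 may carry both forms, so given the size of an 11-fold lower number from compound 2 to compound 3 (1.06 log units; beyond the scatter) a number near the lower of the two is expected. The expected step is small and within the scatter, a 1.8-fold higher number from compound 3 to compound 4 (0.25 log units; within the scatter), towards a higher number. For compound 4 the estimated value is 4800 nM, with an expected range of 2700 nM to 8500 nM.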

Compound 4, half-maximal inhibitory concentration: 9770 nM
Beside the measured number, compound 4's estimate is 2.0-fold (0.31 log units) below it; measured number above the stated range.
By their numbers in this assay, from the lowest: compounds 1 and 3 (each within the scatter of the next); then compound 4; then compound 2.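

Leaving the stereocentre undrawn gives a middle position, with a 3.6-fold higher number from compound 3 to compound 4 (0.56 log units; beyond the scatter) and with a 3.2-fold lower number from compound 2 to compound 4 (0.50 log units; beyond the scatter). That position is read from the drawn structures alone: the fact that one of compounds 3 and 4 is drawn with a defined configuration and the other without, at the place where they differ Hydrogen in place of ethyl on a nitrogen can now be read as a single change, with a 6.5-fold higher number from compound 1 to compound 4 (0.81 log units; beyond the scatter). Going by these compounds, whether compound 4 really holds both forms, and in what proportion, stays open. Also open, on these data alone, is how a longer chain, such as propyl, on that nitrogen would compare.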